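The source may report more compounds than this note shows. Statements on the series, on what has been measured and on what is new or still open speak of the compounds shown alone.

For the measured compounds named here, in a functional assay with Homo sapiens as the target (a higher number here means a weaker inhibitor, a lower number a stronger inhibitor), compound 2 `CC(C)[C@H](NC(=O)COc1cccc2ccccc12)C(=O)N[C@@H](CC(=O)O)C(=O)COc1cc(F)ccc1F` gives 19700 nM, the lower of the two numbers so far; compound 1 `CC(C)[C@H](NC(=O)COc1cccc2ccccc12)C(=O)N[C@@H](CC(=O)O)C(=O)COc1ccccc1[N+](=O)[O-]` gives 27700 nM, which sits within the scatter of compound 2, so no order between the two can be read. Going by the values given here, the only measured step, a 1.4-fold lower number from compound 1 to compound 2 (0.15 log units; within the scatter), is likewise an exchange of the aryl group on the oxygen on a saturated carbon, and it is the one step that bears on what follows. Among the compounds with values here, compound 3 `CC(C)[C@H](NC(=O)COc1cccc2ccccc12)C(=O)N[C@@H](CC(=O)O)C(=O)COc1ccc([N+](=O)[O-])cc1F` is not yet measured in this assay. 2-fluoro-4-nitrophenyl in place of 2,5-difluorophenyl on an oxygen on a saturated carbon The entering group brings back a nitro group, which compound 1 also carries, but as 2-fluoro-4-nitrophenyl rather than 2-nitrophenyl, and no measured step covers that exact arrangement. Given that the sole step at this place stayed within the scatter, and given that compound 1 with its nitro group gives 27700 nM, no step beyond the scatter is expected here. The step of a 1.2-fold higher number from compound 2 to compound 3 (0.07 log units; within the scatter) is estimated to be small. Compound 3 is expected to give 23000 nM, with a range from 9000 nM to 55000 nM.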

Compound 3, half-maximal inhibitory concentration: 15800 nM
Beside the measured number, compound 3's estimate is 1.5-fold (0.16 log units) above it; the range from low to high includes it.
By their numbers in this assay, from the lowest: compounds 3, 2 and 1 (each within the scatter of the next).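

At this place, on an oxygen on a saturated carbon, the series now holds three aryl groups, and in this assay the exchange of 2,5-difluorophenyl for 2-fluoro-4-nitrophenyl gives a 1.2-fold lower number from compound 2 to compound 3 (0.10 log units; within the scatter) even though the entering group counts 10 heavy atoms and 2 hydrogen-bond acceptors against 8 and 0 for the group that leaves. With a nitro group on both sides of the exchange, 2-fluoro-4-nitrophenyl in place of 2-nitrophenyl gives a 1.8-fold lower number from compound 1 to compound 3 (0.24 log units; within the scatter) and so also leaves the two compounds unseparated, which means that among compounds 1, 2 and 3 no aryl group at this place can be ranked above another. No measurement bears on what lies behind these numbers.

As far as these compounds go, whether an aminophenyl group, a phenyl group carrying a carboxylic acid or a plain alkyl chain at this place would give a step beyond the scatter stays open. Also open, from the compounds shown here alone, is how the number responds to a change elsewhere on the shared core, as all three compounds carry the same core and differ only in this aryl group.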